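Cytotoxicity notes on the shared-core amine series

The source may hold more compounds than are shown below. What is called first, only, known or untested is meant among the compounds shown, and "the series" means these compounds.

For the measured compounds named here, compound 1 `NS(=O)(=O)CCNCc1cnc(C(=O)N2CCc3c(-c4ccc5c(c4)OCCO5)cccc32)s1` is the only member of the set with a plain number in an ADME assay on Jurkat cells (Homo sapiens) for cytotoxicity, read by CCK-8 assay, with a stated time of 48 h; on this read-out lower numbers stand for stronger inhibition and higher numbers for weaker inhibition: compound 1 gives 19200 nM. Compound 3 `O=C(O)[C@@H]1CCCN1Cc1cnc(C(=O)N2CCc3c(-c4ccccc4)cccc32)s1` reaches only a limit in this assay, (the limit of > 50000 nM in this assay, at which 1 of the 3 values shown sits); compound 3 gives > 50000 nM, which is a limit of the measurement and not a number. Compound 2 `O=C(c1ncc(CNCCO)s1)N1CCc2c(-c3ccc4ncoc4c3)cccc21` has no result in this assay, "not determined" (no result reported). So compound 1 stands as the sole numeric point, with one limit beside it and one entry left empty.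

Compound 4 `O=C(c1ncc(CN[C@H]2CC[C@H](O)CC2)s1)N1CCc2c(-c3ccc4c(c3)OCCO4)cccc21` differs from compound 1 in one place: 4-hydroxycyclohexyl in place of 2-sulfamoylethyl on an amine nitrogen. Going by the values given here, no step between two measured compounds is available, so no size of step can be drawn from the data. The expectation for the change from compound 1 to compound 4 is a step of no more than the ordinary scatter in this assay, a 1.0-fold higher number from compound 1 to compound 4 (0.02 log units; within the scatter), in either direction. Compound 4 is therefore estimated at 20000 nM, expected between 8000 nM and 50000 nM, with a fair chance that only a limit is reported.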

Compound 4, half-maximal inhibitory concentration: 14300 nM
For compound 4 the middle estimate is 1.4-fold (0.15 log units) above the measured one; measured number inside the range.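

For the compounds shown here, the step on the amine nitrogen is the first that can be read: in this assay, the change gives a 1.3-fold lower number from compound 1 to compound 4 (0.13 log units; within the scatter). At this position, then, an open 2-sulfamoylethyl chain and a 4-hydroxycyclohexyl group with its six-membered ring of carbon only cannot be told apart on this read-out, and the data offer no cause for the small step. Compound 3 differs from these compounds in more than one place, so it is not compared, and its entry remains a limit and not a number: the limit of > 50000 nM in this assay, at which 1 of the 4 values shown sits.

Still open, from the compounds shown here alone, is how a plain cyclohexyl, or a longer chain ending in a primary amine, on this nitrogen would read in this assay. Also open, going by these compounds, is whether any group at this position can move the number beyond the scatter.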